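The compounds below may be only part of what the source reports. "The series", "measured", "known", "first", "only" and "open" are said of these compounds alone.

Series notes. Three amides on the shared core differ only in the amine-bearing side chain on the saturated chain carbon bound to an oxygen on an aromatic ring. Compound 1 `CC(C)=CCc1cc(C(=O)Nc2cc3ccc(OCCC4CCCCN4)c(C)c3oc2=O)ccc1O` gives 710 nM in a functional assay on MCF7 cells (Homo sapiens) for antiproliferative activity; a higher number here means a weaker inhibitor, a lower number a stronger inhibitor. Compound 2 `CC(C)=CCc1cc(C(=O)Nc2cc3ccc(OCC4CCN(C)C4)c(C)c3oc2=O)ccc1O` gives 1550 nM in this assay; of the two numbers shown it is the higher, the gap being a 2.2-fold higher number from compound 1 to compound 2 (0.34 log units; beyond the scatter). Compound 3 `CC(C)=CCc1cc(C(=O)Nc2cc3ccc(OCCCN4CCCCC4)c(C)c3oc2=O)ccc1O` reaches only the limit of this assay, reported as > 50000 nM. From there an at least 70-fold higher number from compound 1 to compound 3 (1.84 log units; beyond the scatter) and an at least 32-fold higher number from compound 2 to compound 3 (1.50 log units; beyond the scatter), both large, stand against the modest 2.2-fold higher number from compound 1 to compound 2 (0.34 log units; beyond the scatter).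

Compound 4 `CC(C)=CCc1cc(C(=O)Nc2cc3ccc(OCCCNCC(=O)O)c(C)c3oc2=O)ccc1O` is not yet measured. It differs from compound 2 by 2-((carboxymethyl)amino)ethyl in place of 1-methylpyrrolidin-3-yl on a saturated chain carbon bound to an oxygen on an aromatic ring. Given an at least 32-fold higher number from compound 2 to compound 3 (1.50 log units; beyond the scatter), the one measured step that also removes the 1-methylpyrrolidin-3-yl group in favour of an open chain on that carbon, compound 4 is expected to show a 13-fold higher number from compound 2 to compound 4 (1.11 log units; beyond the scatter). For compound 4 the limit of > 50000 nM in this assay, at which 1 of the 3 values shown sits, is a real possibility. Compound 4 is estimated at 20000 nM, with a range from 5000 nM to 50000 nM.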

Compound 4, half-maximal inhibitory concentration: 18100 nM
The estimate for compound 4 lay 1.1-fold (0.04 log units) above the measured number, within the range that was stated.
By their numbers in this assay, from the lowest: compound 1; then compound 2; then compound 4. At a limit, above all of these: compound 3.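

In this assay an open chain on this carbon does not by itself mean a value at the limit: (carboxymethyl)amino in place of piperidin-1-yl gives a measurable number (an at least 2.7-fold lower number from compound 3 to compound 4 (0.44 log units; beyond the scatter)), though that step's size is only a bound. Compound 3 remains a limit and not a number: the limit of > 50000 nM in this assay, at which 1 of the 4 values shown sits. The 1-methylpyrrolidin-3-yl and (piperidin-2-yl)methyl side chains still lead the 2-((carboxymethyl)amino)ethyl side chain by large steps (a 12-fold higher number from compound 2 to compound 4 (1.07 log units; beyond the scatter); a 25-fold higher number from compound 1 to compound 4 (1.41 log units; beyond the scatter)).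

Whether the difference between compound 3 and compound 4 follows the carboxylic acid or the open secondary amine stays unresolved. An ester of that acid, a plain primary amine on the same chain, or a longer chain would separate these readings, and none stands among the compounds shown.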